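This account rests on a few compounds, and the source may have more. Where it says the series, first, only, none or still open, it means among the compounds named here.

Measured in a functional assay on BaF3 cells (Mus musculus) for inhibition, read by CCK-8 assay, with a stated time of 72 h; on this read-out higher numbers stand for weaker inhibition of growth and lower numbers for stronger inhibition of growth:
- Compound 1 `CCN1CCN(Cc2ccc(NC(=O)Nc3ccc(Oc4cc(NC(C)=O)ncn4)cc3)cc2C(F)(F)F)CC1`: 38 nM
- Compound 2 `CC(=O)Nc1cc(Oc2ccc(NC(=O)Nc3ccc(C)c(C(F)(F)F)c3)cc2)ncn1`: 3230 nM

Of these two values, compound 2 at 3230 nM has the higher number and so shows the weaker inhibition of growth. Going by the values given here, the one measured step is an 85-fold higher number from compound 1 to compound 2 (1.93 log units; beyond the scatter), with hydrogen in place of 4-ethylpiperazin-1-yl on a saturated chain carbon bound to an aromatic carbon.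

Compound 3 `Cc1ccc(NC(=O)Nc2ccc(Oc3cc(N4CCNC[C@H]4C)ncn3)cc2)cc1C(F)(F)F`, not yet measured, differs from compound 2 at another place, with 2-methylpiperazin-1-yl in place of acetamido on an aromatic carbon. Among the compounds with values here, no measured step touches the acetamido group, so the data do not show what its removal does. The step to compound 2, an 85-fold higher number from compound 1 to compound 2 (1.93 log units; beyond the scatter), is large but lies elsewhere on the molecule, so it bears on this change only loosely, and a step of that size is not expected here. In this assay, a step without a firm direction, within the scatter or little beyond it, is expected. The expected step is a 1.6-fold lower number from compound 2 to compound 3 (0.21 log units; within the scatter). Compound 3 is estimated at 2000 nM, with an expected range from 400 nM to 8000 nM.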

Compound 3, concentration for 50% growth inhibition: 9670 nM
Compound 3: the middle estimate sits 4.8-fold (0.68 log units) below what was measured; measured number above the stated range.
By their numbers in this assay, from the lowest: compound 1; then compound 2; then compound 3.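

In this assay, going by these compounds alone, the exchange of acetamido for 2-methylpiperazin-1-yl on this aromatic carbon, next to the ring nitrogen, gives a 3.0-fold higher number from compound 2 to compound 3 (0.48 log units; beyond the scatter) and is the first measured step at this place. It shows that the position is not indifferent to what it carries, since the step lies beyond the scatter, though it is only modest in size and much smaller than an 85-fold higher number from compound 1 to compound 2 (1.93 log units; beyond the scatter) at the other end of the molecule. In this one pair the entering group, with its non-aromatic ring and defined stereocentre, goes with weaker inhibition of growth, and nothing here gives a reason for that.

Within the data shown here, because the exchange removes acetamido and brings in the ring together, the single pair cannot separate the loss of one from the arrival of the other, and the separate parts played by the methyl group and the stereocentre also stay unknown. As far as these compounds go, it remains open how an unsubstituted piperazine, a morpholine or a simple dimethylamino group would behave here, and whether the step would hold with the 4-ethylpiperazin-1-yl group of compound 1 present.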